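The compounds below may be only part of what the source reports. "The series", "measured", "known", "first", "only" and "open" are said of these compounds alone.

Measured compounds:
- compound 1, `CN1CCN(c2ccc(Nc3ncc4nc(Nc5ccc(F)cc5)n([C@@H]5CCN(C(=O)CO)C5)c4n3)cc2)CC1`: 350 nM
- compound 2, `CN1CCN(c2ccc(Nc3ncc4nc(Nc5ccccc5)n([C@H]5CCNC5)c4n3)cc2)CC1`: 530 nM
- compound 3, `CN1CCN(c2ccc(Nc3ncc4nc(Nc5ccc(F)cc5)n([C@@H]5CCCNC5)c4n3)cc2)CC1`: 120 nM

These three share one core and were tested in a functional assay on HCC827 cells (Homo sapiens) for antiproliferative activity, read by MTT assay, with a stated time of 72 h; on this read-out higher numbers stand for weaker inhibition and lower numbers for stronger inhibition. Compound 1 gives 350 nM, compound 3 gives 120 nM, and compound 2 gives 530 nM. The number for compound 2 lies within the scatter of that for compound 1, so the two cannot be told apart, while the gap to compound 3 lies beyond the scatter.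

Compound 4, `CC(=O)N1CC[C@H](n2c(Nc3ccccc3)nc3cnc(Nc4ccc(N5CCN(C)CC5)cc4)nc32)C1`, has not yet been measured. It differs from compound 2 by acetyl in place of hydrogen on an amine nitrogen in a ring. Going by the values given here, no measured step removes or adds an acetyl group alone. Among the compounds with values here, the only step with an acyl group on that ring nitrogen is a 2.9-fold lower number from compound 1 to compound 3 (0.46 log units; beyond the scatter), but there the ring size changed as well, so it cannot be cleanly read as the effect of the acyl group. Compound 1, which carries an acylated five-membered ring, and compound 2, which carries a free one, sit within the scatter of each other, which suggests that acylation by itself shifts little.

Compound 4 is therefore expected to come out near compound 2, with the expected step being a 1.3-fold lower number from compound 2 to compound 4 (0.10 log units; within the scatter). The estimated value for compound 4 in this assay is 420 nM, with a range from 150 nM to 1200 nM.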

Compound 4, half-maximal inhibitory concentration: 260 nM
The estimate for compound 4 lay 1.6-fold (0.21 log units) above the measured number, and the stated range covers the measured number.
By their numbers in this assay, from the lowest: compound 3; then compounds 4, 1 and 2 (each within the scatter of the next, the first and the last beyond it).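

In this assay, putting acetyl in place of hydrogen on the amine nitrogen of the five-membered ring, with nothing else altered, gives a 2.0-fold lower number from compound 2 to compound 4 (0.31 log units; beyond the scatter), a modest shift that lies just beyond the usual scatter. The earlier step, a 2.9-fold lower number from compound 1 to compound 3 (0.46 log units; beyond the scatter), could not isolate the group on this nitrogen. The ring size changed in that step at the same time. This pair, by contrast, shows that, on this five-membered ring, the free amine hydrogen is not needed to keep this level of inhibition and that an acetyl group here does not weaken it. What lies behind the shift remains unexplained, as nothing measured here speaks to its cause.

Going by these compounds, it remains open whether the same shift would appear with a different group on this nitrogen, such as a simple methyl, a longer acyl chain or a methanesulfonyl group. On these data alone, it is also open whether acetyl would act in the same way on the piperidin-3-yl ring of compound 3, where the nitrogen is free and the number is the lowest of the set.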